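Cinnamamide series: amino-methoxyphenyl variant of compound 2

This account rests on a few compounds, and the source may have more. Where it says the series, first, only, none or still open, it means among the compounds named here.

Among the measured compounds shown here, compound 2 `COc1cccc(/C=C/C(=O)Nc2cc(C(=O)c3cc(OC)c(OC)c(OC)c3)cc(OC)c2OC)c1` gives 13300 nM in a functional assay on PC-3 cells (Homo sapiens) for cytotoxicity, read by MTT assay, with a stated time of 72 h (on this read-out lower numbers stand for stronger inhibition and higher numbers for weaker inhibition), the highest of the two numbers so far; compound 1 `COc1ccc(/C=C/C(=O)Nc2cc(C(=O)c3cc(OC)c(OC)c(OC)c3)cc(OC)c2OC)cc1` gives 6300 nM. For the measured compounds named here, the only measured step is a 2.1-fold higher number from compound 1 to compound 2 (0.32 log units; beyond the scatter). Compound 3 `COc1ccc(/C=C/C(=O)Nc2cc(C(=O)c3cc(OC)c(OC)c(OC)c3)cc(OC)c2OC)cc1N` differs from compound 2 by 3-amino-4-methoxyphenyl in place of 3-methoxyphenyl on a double-bonded chain carbon bound to a double-bonded chain carbon, on a double-bonded chain carbon bound to a double-bonded chain carbon. Going by the values given here, the change restores the 4-methoxy arrangement of compound 1 and adds an amino group, for which no step is measured. A modest step down toward compound 1 is expected, a 3.3-fold lower number from compound 2 to compound 3 (0.52 log units; beyond the scatter). Compound 3 is therefore estimated at 4000 nM, within 1500 nM to 12000 nM.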

Compound 3, half-maximal inhibitory concentration: 11100 nM
Compound 3: middle estimate off by 2.8-fold (0.44 log units), on the low side, within the range that was stated.
By their numbers in this assay, from the lowest: compounds 1, 3 and 2 (each within the scatter of the next, the first and the last beyond it).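

In this assay amino in place of hydrogen on an aromatic carbon gives a 1.8-fold higher number from compound 1 to compound 3 (0.25 log units; within the scatter) and 3-amino-4-methoxyphenyl in place of 3-methoxyphenyl gives a 1.2-fold lower number from compound 2 to compound 3 (0.08 log units; within the scatter) as the second reading at this place. Compound 3 is therefore not separated from either compound 1 or compound 2, although those two remain apart beyond the scatter, so the amino group brings no clear change on this read-out. No evidence on hand bears on this result.

Open, on these data alone, is whether a hydroxyl or a dimethylamino group in place of the amino group would give a step beyond the scatter from compound 1.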